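Removing the fluorine from the best benzamide of this set

The source may report more compounds than this note shows. Statements on the series, on what has been measured and on what is new or still open speak of the compounds shown alone.

Three compounds share one core and differ only in the group on the carbonyl carbon of the amide. Compound 1 `CCN1CCN(c2cc(C)c3cc(NC(=O)c4cccc(F)c4)ccc3n2)CC1` carries a 3-fluorophenyl there and in a functional assay on MCF7 cells (Homo sapiens) for antiproliferative activity, read by MTT assay, with a stated time of 72 h (on this read-out lower numbers stand for stronger inhibition and higher numbers for weaker inhibition), compound 1 gives 8920 nM. Compound 2 `CCN1CCN(c2cc(C)c3cc(NC(=O)c4ccco4)ccc3n2)CC1` carries a furan-2-yl, and in this assay compound 2 gives 41200 nM. Compound 3 `CCN1CCN(c2cc(C)c3cc(NC(=O)c4ccc(F)cc4)ccc3n2)CC1` carries a 4-fluorophenyl, and in this assay compound 3 gives 4030 nM, the lowest number of the three. The measured steps are a 2.2-fold lower number from compound 1 to compound 3 (0.35 log units; beyond the scatter), a 4.6-fold higher number from compound 1 to compound 2 (0.66 log units; beyond the scatter) and a 10-fold lower number from compound 2 to compound 3 (1.01 log units; beyond the scatter), so moving the fluorine around the ring changed the number modestly, while swapping the ring for a furan changed it a great deal.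

Compound 4 `CCN1CCN(c2cc(C)c3cc(NC(=O)c4ccccc4)ccc3n2)CC1` is the unsubstituted benzoyl analogue. Against compound 3 the change is hydrogen in place of fluoro on an aromatic carbon. Among the measured compounds shown here, no measured step removes a fluorine outright, so the closest guide is the modest step between compound 1 and compound 3, which suggests the fluorine matters but not greatly. Compound 4 is therefore expected to sit near compound 3, with a 1.5-fold higher number from compound 3 to compound 4 (0.17 log units; within the scatter) as the expected step, likely within the scatter. Compound 4 is estimated at 6000 nM, with a range from 2500 nM to 15000 nM.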

Compound 4, half-maximal inhibitory concentration: 14200 nM
For compound 4 the middle estimate is 2.4-fold (0.37 log units) below the measured one; measured number inside the range.
By their numbers in this assay, from the lowest: compound 3; then compounds 1 and 4 (each within the scatter of the next); then compound 2.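

Taking the fluorine off the 4-fluorophenyl ring gives a 3.5-fold higher number from compound 3 to compound 4 (0.55 log units; beyond the scatter) in this assay, so this fluorine counts for more than the earlier comparison of the two fluorophenyl compounds could show. A fluorine on the ring does not help wherever it stands, however: the step for the 3-fluorophenyl group is a 1.6-fold higher number from compound 1 to compound 4 (0.20 log units; within the scatter), which lies within the scatter, so only the 4-fluorophenyl group separates from the plain phenyl. The plain phenyl group also gives a 2.9-fold lower number from compound 2 to compound 4 (0.46 log units; beyond the scatter), which splits the large gap between the furan and the 4-fluorophenyl compound into two modest parts, one that goes with changing the ring and one that goes with adding the fluorine.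

The data offer no measurement that explains why the fluorine counts at one ring position and not at the other. On these data alone, it also remains open whether the gain belongs to fluorine alone or whether another group on the same ring carbon, such as chlorine, a methoxy group or an amine, would give a similar or larger change.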